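A few compounds are considered here, and "the series" means these few. Any claim that something is new, unique, unknown or untested is made for them only; others in the source may bear on it.

Measured so far:
compound 1, `Cc1cc(C)nc(N(CCNC(C)C)C(=O)N(C)C)c1`, gives 33%
compound 2, `CCCN(CCC)CCN(C(=O)N(C)C)c1cc(C)cc(C)n1`, gives 22%
compound 3, `Cc1ccnc(N(CCN(C(C)C)C(C)C)C(=O)N(C)C)c1`, gives 95%

All three numbers come from a functional assay on the whole organism (stomach) for inhibition, with Canis familiaris (Canis lupus familiaris) as the target, at a dose of 20 mg/kg by the oral route; a lower number here means a weaker effect, a higher number a stronger effect of the compound at the dose given. Among them compound 3 stands highest, well beyond the scatter above both others. Going by the values given here, the only change measured in one place is a number 11 percentage points lower from compound 1 to compound 2 (beyond the scatter), a modest drop that concerns the amine at the end of the saturated chain, not the aromatic ring group.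

Compound 4, `CC(C)N(CCN(C(=O)N(C)C)c1ccc(Cl)cn1)C(C)C`, differs from compound 3 in one place: 5-chloropyridin-2-yl in place of 4-methylpyridin-2-yl on an amide-type nitrogen. Among the compounds with values here, nothing measured bears on this change, since no step among the three compounds touches the six-membered aromatic ring with one hetero atom; the one known step, from compound 1 to compound 2, alters a different part of the molecule. From the compounds shown here alone, the expectation for compound 4 therefore rests only on the high value of compound 3 in this assay, with a wide allowance for a swap whose effect is unknown. A moderate loss is taken as the middle case, so the step of a number 25 percentage points lower from compound 3 to compound 4 (beyond the scatter) is expected to be downward but uncertain in size. Compound 4 is estimated to give 70%, with a range from 35% to 95%.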

Compound 4, a percentage reported as inhibition, in the whole organism at one dose (the size of the read-out at that dose, not a potency): 63%
Compound 4: middle estimate off by 7 percentage points, on the high side, within the range that was stated.
By their numbers in this assay, from the lowest: compound 2; then compound 1; then compound 4; then compound 3.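

In this assay, going by these compounds alone, the aromatic ring on the amide-type nitrogen proves to be a sensitive part of the molecule: 5-chloropyridin-2-yl in place of 4-methylpyridin-2-yl gives a number 32 percentage points lower from compound 3 to compound 4 (beyond the scatter), a large step, whereas the only earlier one-place change, at the amine end of the chain, gave the modest a number 11 percentage points lower from compound 1 to compound 2 (beyond the scatter). The loss is only partial, since compound 4 still gives 63%, and the swap alters two things at once, replacing methyl with chloro and moving the substituent from the 4 position named in the old group to the 5 position named in the new one. Nothing available here explains why the number falls, so the step stands as an observation only.

From the compounds shown here alone, what remains open is whether the drop follows from the chlorine itself or from where it sits, a question that 4-chloropyridin-2-yl and 5-methylpyridin-2-yl would help to separate. It is also unclear how a plain phenyl ring or a 5-fluoropyridin-2-yl group would behave at this nitrogen, with the rest of compound 3 kept the same.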